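A few compounds are considered here, and "the series" means these few. Any claim that something is new, unique, unknown or untested is made for them only; others in the source may bear on it.

Compound 1 `CCCCCCCCOc1nc(N)nc2c1ncn2/C=C1/CC1(CO)CO` gives > 20000 nM in an ADME assay on BCBL1 cells (Homo sapiens) for cytotoxicity, with a stated time of 7 days (on this read-out lower numbers stand for higher toxicity in this test and higher numbers for lower toxicity in this test), which is a limit of the test rather than a number.
Compound 2 `CSc1nc(N)nc2c1ncn2/C=C1/CC1(CO)CO` gives > 20000 nM in this assay, again a limit.

Going by the values given here, compound 1 therefore stands only at a limit in this assay, and the one step that touches it, a step that the two limits leave unreadable from compound 1 to compound 2, cannot be sized because of the limit of > 20000 nM in this assay, at which 2 of the 2 values shown sit. Compound 3 `CCCOc1nc(N)nc2c1ncn2/C=C1/CC1(CO)CO` differs from compound 1 by hydrogen in place of pentyl on a saturated chain carbon, three bonds along the chain from an oxygen on an aromatic ring. Among the compounds with values here, no measured step gives a readable size for this kind of change, and the two measured compounds show no toxicity within the range of the test. On that basis compound 3 is expected to behave like them, with the step from compound 1 expected to be a step that the limit leaves unreadable from compound 1 to compound 3, nothing beyond the scatter. Compound 3 is thus estimated at 25000 nM in this assay, with a likely range from 12000 nM to 60000 nM, and most probably reported only as a limit.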

Compound 3, half-maximal cytotoxic concentration: > 20000 nM
Compound 3 was reported as a limit; the forecaster's own chance of this, stated with the estimate: 80%; the middle value is on the limit's open side.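

Compound 3 joins compound 1 and compound 2 at a limit in this assay, so none of the steps among these three compounds can be read, because every value is a limit: the limit of > 20000 nM in this assay, at which 3 of the 3 values shown sit.

The compounds shown leave open whether the octyloxy, propoxy and methylsulfanyl compounds differ in toxicity at all.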